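Swapping a benzyl ether for a trifluoroacetamidopropyl chain

The source may hold more compounds than are shown below. What is called first, only, known or untested is meant among the compounds shown, and "the series" means these compounds.

Of the compounds shown here, three sharing one core have been measured in a physicochemical assay for solubility, in phosphate buffer, with a stated time of 18 h, at pH 7.4; on this read-out higher numbers stand for higher solubility and lower numbers for lower solubility. Compound 1 `COc1cc2ncnc(-n3nc(-c4ccccc4)nc3N)c2cc1OC` gives 1000 nM, compound 2 `CCN(CC)c1nc(-n2nc(-c3ccccn3)nc2N)c2cc(OC)c(OC)cc2n1` gives 6000 nM, and compound 3 `COc1cc2ncnc(-n3nc(-c4ccccn4)nc3N)c2cc1OCc1ccccc1` gives 58000 nM. On these numbers compound 3 stands highest: compound 2 comes nearest, with a lower number that lies beyond the scatter, and compound 1 lies furthest, also beyond the scatter. No two of these compounds differ in a single place, so none of the gaps can be tied to one change.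

Compound 4 `COc1cc2ncnc(-n3nc(-c4ccccn4)nc3N)c2cc1OCCCNC(=O)C(F)(F)F` has not yet been measured in this assay. It departs from compound 3 as follows: 2-(((trifluoromethyl)carbonyl)amino)ethyl in place of phenyl on a saturated chain carbon bound to an oxygen on an aromatic ring. Cut one bond further out, the change reads benzyl to 3-(((trifluoromethyl)carbonyl)amino)propyl, or benzyloxy to 3-(((trifluoromethyl)carbonyl)amino)propoxy. Among the measured compounds shown here, no measured pair shows this change, so the expectation rests on the standing of compound 3 alone and on what is counted in the entering group. The step from compound 3 to compound 4 is expected to be a modest rise, as a 1.7-fold higher number from compound 3 to compound 4 (0.24 log units; within the scatter), though a result within the scatter would not surprise. For compound 4 the estimated value is 100000 nM, with a range from 30000 nM to 300000 nM.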

Compound 4, solubility: 1000 nM
Beside the measured number, compound 4's estimate is 100-fold (2.00 log units) above it; the whole stated range lies above it.
By their numbers in this assay, from the lowest: compounds 1 and 4 (each within the scatter of the next); then compound 2; then compound 3.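

In this assay, putting the 3-(((trifluoromethyl)carbonyl)amino)propyl chain on the oxygen in place of benzyl gives a 58-fold lower number from compound 3 to compound 4 (1.76 log units; beyond the scatter). Among the compounds shown here, this is the only step here that can be tied to one change, and it shows that the read-out is far from indifferent to what this position carries, at least on the core that these two compounds share. The change removes a six-membered aromatic ring of carbon only and brings in a chain with no ring, along with fluorine, a double bond outside aromatic rings and a hydrogen-bond donor and acceptor, and nothing available gives a reason for the fall.

The compounds shown leave open which of these differences goes with the lower number: a plain propyl ether, or a propyl chain ending in a free amine or in an acetyl amide without fluorine, would separate the chain from its trifluoromethyl carbonyl end. Also open, on these data alone, is whether a carboxylic acid at the end of the chain, or a shorter or longer chain, would stand nearer to compound 3 or to compound 4.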